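The source may report more compounds than this note shows. Statements on the series, on what has been measured and on what is new or still open speak of the compounds shown alone.

In an ADME assay on HUVEC cells (Homo sapiens) for cytotoxicity, read by MTT assay, with a stated time of 24 h (on this read-out higher numbers stand for lower toxicity in this test and lower numbers for higher toxicity in this test), compound 1 `Fc1ccc(/C=C/c2nnc(-c3ccc4c(c3)OCCO4)o2)cc1` gives 325000 nM and compound 2 `Clc1ccc(/C=C/c2nnc(-c3ccc4c(c3)OCCO4)o2)cc1` gives 312000 nM in the same test. Among the measured compounds shown here, the only measured step (a 1.0-fold lower number from compound 1 to compound 2 (0.02 log units; within the scatter)), chloro in place of fluoro on an aromatic carbon, lies within the scatter, so compound 2 stands level with compound 1. Compound 3 `COc1cccc(/C=C/c2nnc(-c3ccc4c(c3)OCCO4)o2)c1` carries 3-methoxyphenyl in place of 4-chlorophenyl on a double-bonded chain carbon bound to a double-bonded chain carbon. For the measured compounds named here, no measured compound has a methoxy group, so compound 2 at 312000 nM and that one small step are a thin guide, and no shift beyond the scatter is expected. The expected step is small (a 1.1-fold lower number from compound 2 to compound 3 (0.05 log units; within the scatter)). Compound 3 is estimated at 280000 nM in this assay (expected range 140000 nM to 500000 nM).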

Compound 3, half-maximal cytotoxic concentration: 332000 nM
The estimate for compound 3 lay 1.2-fold (0.07 log units) below the measured number; the measured number falls inside the stated range.
By their numbers in this assay, from the lowest: compounds 2, 1 and 3 (each within the scatter of the next).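

In this assay, 3-methoxyphenyl in place of 4-chlorophenyl gives a 1.1-fold higher number from compound 2 to compound 3 (0.03 log units; within the scatter), and 3-methoxyphenyl in place of 4-fluorophenyl gives a 1.0-fold higher number from compound 1 to compound 3 (0.01 log units; within the scatter). At this position, then, a ring bearing methoxy reads level with rings bearing a halogen, so the change at this place is not limited to swapping one halogen for another. Nothing measured accounts for this level reading.

Going by these compounds, whether an amine or a carboxylic acid on this ring would move the number beyond the scatter stays open. The same holds for a longer chain in place of methoxy.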